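Indole oxyacetic acid series: cyclohexyl versus cyclohexylmethyl step

The source may hold more compounds than are shown below. What is called first, only, known or untested is meant among the compounds shown, and "the series" means these compounds.

Measured so far:
- compound 1, `Cc1cn(Cc2ccc(O)c(C(C)(C)C)c2)c2ccc(OCC(=O)O)cc12`: 9.98 nM
- compound 2, `Cc1cn(Cc2ccc(O)c(CC3CCCCC3)c2)c2ccc(OCC(=O)O)cc12`: 46.6 nM

In an assay on HeLa cells for displacement of a labelled ligand from thyroid hormone receptor alpha (Homo sapiens) (on this read-out higher numbers stand for weaker inhibition and lower numbers for stronger inhibition), compound 1 gives 9.98 nM and compound 2 gives 46.6 nM. Within the data shown here, compound 2 stands at the higher of the two numbers; the single step, a 4.7-fold higher number from compound 1 to compound 2 (0.67 log units; beyond the scatter), is beyond the scatter and counts as modest.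

The next compound, compound 3 `Cc1cn(Cc2ccc(O)c(C3CCCCC3)c2)c2ccc(OCC(=O)O)cc12`, is not yet measured. It differs from compound 2 by cyclohexyl in place of cyclohexylmethyl on an aromatic carbon, sitting ortho to a hydroxy group and meta to a large group on the same aromatic carbon that carried the earlier variation.

Among the measured compounds shown here, only one measured step bears on this change, a 4.7-fold higher number from compound 1 to compound 2 (0.67 log units; beyond the scatter), and it covers a different swap, tert-butyl to cyclohexylmethyl, so it gives direction rather than a direct read. Cyclohexyl shares with tert-butyl the branching at the carbon joined to the ring, so a move back toward the number of compound 1 is the expectation, though smaller than the full return. For compound 3 the expected step is a 2.3-fold lower number from compound 2 to compound 3 (0.37 log units; beyond the scatter) in this assay. Compound 3 is therefore estimated at 20 nM, with a range of 7 nM to 60 nM.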

Compound 3, inhibition constant: 200 nM
For compound 3 the middle estimate is 10-fold (1.00 log units) below the measured one, outside the stated range (above it).
By their numbers in this assay, from the lowest: compound 1; then compound 2; then compound 3.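

Working through this assay, the tert-butyl and cyclohexyl groups on this aromatic carbon, ortho to a hydroxy group, prove far from interchangeable, with cyclohexyl in place of tert-butyl giving a 20-fold higher number from compound 1 to compound 3 (1.30 log units; beyond the scatter), although both groups are branched at the carbon joined to the ring. Cyclohexylmethyl has 7 heavy atoms and cyclohexyl has 6, and both carry the same carbon ring. Cyclohexyl in place of cyclohexylmethyl gives a 4.3-fold higher number from compound 2 to compound 3 (0.63 log units; beyond the scatter), so the numbers do not rise simply with group size: among these three compounds, the cyclohexyl of compound 3 gives the highest number, while the larger cyclohexylmethyl of compound 2 goes against a size trend. Nothing available accounts for this order.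

Still open, from the compounds shown here alone, is where isopropyl or cyclopentyl would fall at this position, which would show whether the high number belongs to cyclohexyl alone or extends to other branched groups. A longer chain such as 2-cyclohexylethyl would also test whether moving the ring further from the aromatic carbon continues the change seen on going from cyclohexyl to cyclohexylmethyl.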